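Ester on the side chain of a quinone-fused triazole

A few compounds are considered here, and "the series" means these few. Any claim that something is new, unique, unknown or untested is made for them only; others in the source may bear on it.

Of the compounds shown here, two of a shared core have been measured in a functional assay on KB cells (Homo sapiens) for inhibition, read by colorimetric assay, with a stated time of 72 h; on this read-out lower numbers stand for an effect already at smaller amounts and higher numbers for an effect only at larger amounts of compound. Compound 1, with the structure `COC(=O)Cn1nc2c(n1)C(=O)C(C)=C(C)C2=O`, gives 4 ug/mL in this assay. Compound 2, with the structure `CC1=CC(=O)c2nn(C)nc2C1=O`, gives 2.5 ug/mL. Compound 2 has the lowest of the two numbers, but the gap to compound 1 is within the scatter of the method, so the two cannot be set apart on this evidence.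

The next compound, compound 3, has the structure `COC(=O)Cn1nc2c(n1)C(=O)C(C)=CC2=O`. It differs from compound 2 in one place: methoxycarbonyl in place of hydrogen on a saturated chain carbon bound to an aromatic nitrogen, which read one bond further out is methyl to (methoxycarbonyl)methyl. Among the measured compounds shown here, no measured pair shows this change on its own. Compound 1, however, already carries a (methoxycarbonyl)methyl group and gives a number close to that of compound 2, which gives little reason to expect a large shift in either direction. Compound 3 is therefore expected to give about 3.5 ug/mL in this assay, with a range from 1.2 ug/mL to 10 ug/mL. The step from compound 2 to compound 3 is estimated at a 1.4-fold higher number from compound 2 to compound 3 (0.15 log units; within the scatter), no more than the scatter.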

Compound 3, concentration for half-maximal effect: 1.5 ug/mL
For compound 3 the middle estimate is 2.3-fold (0.37 log units) above the measured one; the range from low to high includes it.
By their numbers in this assay, from the lowest: compounds 3, 2 and 1 (each within the scatter of the next, the first and the last beyond it).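

In this assay, the change from methyl to (methoxycarbonyl)methyl gives a 1.7-fold lower number from compound 2 to compound 3 (0.22 log units; within the scatter), so this pair shows that the larger ester side chain can be carried with no shift that could be claimed beyond the scatter. The step that does stand clear of the scatter lies in another place: hydrogen in place of methyl on a double-bonded ring carbon gives a 2.7-fold lower number from compound 1 to compound 3 (0.43 log units; beyond the scatter), a modest step that rests on this single pair. Nothing at hand speaks to the origin of either step.

The compounds shown leave open whether a carboxylic acid, an amide or a longer chain in place of the methoxycarbonyl would keep the number in this range. They also leave open whether the step from methyl to hydrogen on the double-bonded ring carbon would recur with a plain methyl in place of the (methoxycarbonyl)methyl side chain, and how an amine or a chlorine atom on that ring carbon would read.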